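Compound 3 to compound 4: a change on the carbonyl

A few compounds are considered here, and "the series" means these few. Any claim that something is new, unique, unknown or untested is made for them only; others in the source may bear on it.

- compound 1 `COCCOCc1cn(Cc2ccc(F)cc2)c2cnc(C(=O)N(C)O)cc12`: > 100000 nM
- compound 2 `CN(O)C(=O)c1cc2c(COC3CCOCC3)cn(Cc3ccc(F)cc3)c2cn1`: > 100000 nM
- compound 3 `CN(O)C(=O)c1cc2c(C(=O)N3CCC[C@@H]3CO)cn(Cc3ccc(F)cc3)c2cn1`: > 32000 nM

All three readings come from an ADME assay on CEM-SS cells (Homo sapiens) for cytotoxicity, read by XTT assay (on this read-out higher numbers stand for lower toxicity in this test and lower numbers for higher toxicity in this test), and each is a limit, not a number. Compound 3 gives > 32000 nM, which is a limit.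

Compound 4 `CC(C)NC(=O)c1cn(Cc2ccc(F)cc2)c2cnc(C(=O)N(C)O)cc12` is not yet measured. It carries isopropylamino in place of 2-(hydroxymethyl)pyrrolidin-1-yl on a carbonyl carbon.

The nearest guides are a step that the two limits leave unreadable from compound 1 to compound 3 and a step that the two limits leave unreadable from compound 2 to compound 3. A third is a step that the two limits leave unreadable from compound 1 to compound 2. None has a readable size, so no direction can be expected from them. The expected change is a step that the limit leaves unreadable from compound 3 to compound 4. For compound 4 the estimate is 60000 nM, with an expected range from 20000 nM to 150000 nM.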

Compound 4, half-maximal cytotoxic concentration: > 100000 nM
Compound 4 ended at the assay's limit; the forecaster's own chance of this, stated with the estimate: 85%; middle value at least 1.6-fold (0.22 log units) away from the limit.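

Within the data shown here, no step to compound 4 from compound 1, compound 2 or compound 3 can be read: all four values are limits, not numbers. The compounds shown leave open whether these group changes alter toxicity at all, and in which direction.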